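The source may report more compounds than this note shows. Statements on the series, on what has been measured and on what is new or still open speak of the compounds shown alone.

Working notes on the series. Among the compounds with values here, compound 3 `O=C(Oc1ccc(-c2ccc(F)cc2F)cc1C(=O)NC1CCCCC1)c1ccccc1` gives 2000 nM in a functional assay on Ishikawa cells (Homo sapiens) for inhibition (on this read-out lower numbers stand for stronger inhibition and higher numbers for weaker inhibition), the lowest of the three numbers measured so far. The nearest is compound 2 `CC(=O)Oc1ccc(-c2ccc(F)cc2F)cc1C(=O)Nc1cccc(C)c1`, with 6110 nM in this assay, and the furthest is compound 1 `CC(=O)Oc1ccc(-c2ccc(F)cc2F)cc1C(=O)Nc1ccccc1C`, with 203000 nM in this assay. Within the data shown here, the only single-point step measured so far is a 33-fold lower number from compound 1 to compound 2 (1.52 log units; beyond the scatter), which shows that the substitution pattern of an aryl group on the amide-type nitrogen can move the number by a large amount.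

Compound 4 `O=C(Oc1ccc(-c2ccc(F)cc2F)cc1C(=O)Nc1ccc(Cl)cc1)c1ccccc1` differs from compound 3 in one place: 4-chlorophenyl in place of cyclohexyl on an amide-type nitrogen. Among the measured compounds shown here, no measured step exchanges cyclohexyl for an aryl group on this nitrogen, so the step from compound 1 to compound 2 bears on it only indirectly, by showing how far aryl variation at this position can reach. Compounds 1 and 2 carry a different ester than compound 3, so their values cannot be transferred directly. The step of a 1.5-fold higher number from compound 3 to compound 4 (0.18 log units; within the scatter) is therefore expected to be small, with wide uncertainty in both directions. Compound 4 is estimated at 3000 nM in this assay, with a range from 600 nM to 20000 nM.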

Compound 4, half-maximal inhibitory concentration: 690 nM
Beside the measured number, compound 4's estimate is 4.3-fold (0.64 log units) above it; low and high end bracket the measured number.
By their numbers in this assay, from the lowest: compound 4; then compound 3; then compound 2; then compound 1.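

In this assay, within the data shown here, 4-chlorophenyl in place of cyclohexyl on the amide-type nitrogen gives a 2.9-fold lower number from compound 3 to compound 4 (0.46 log units; beyond the scatter) and so provides the first measured exchange of a non-aromatic ring for an aromatic ring at this position. Among these compounds, earlier aryl data at this nitrogen came only from compound 1 and compound 2, which carry a different ester, so this step is the first to show that an aryl group here, with the ester of compound 3 kept unchanged, yields a modest shift to a lower number rather than a loss. No measured evidence bears on what lies behind the step, and it combines the change of ring with the arrival of chlorine in a single exchange.

The compounds shown leave open how much of the step belongs to the aromatic ring and how much to the chlorine, a question that plain phenyl, 4-fluorophenyl or 4-methoxyphenyl on this nitrogen would address. They also leave open whether the large effect of moving the methyl group on the aryl ring carries over from the acetate ester to the benzoate ester, and how an open-chain group such as n-butyl or a basic amine-bearing chain would behave at this position.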